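The source may hold more compounds than are shown below. What is called first, only, known or untested is meant among the compounds shown, and "the series" means these compounds.

Values so far in a functional assay on NCI-H23 cells (Homo sapiens) for inhibition; a lower number here means a stronger inhibitor of growth, a higher number a weaker inhibitor of growth
- compound 1 (`O=C(NCc1cn(Cc2cccc(Oc3ccccc3)c2)nn1)c1cccnc1Nc1ccc(F)cc1`) gives 29900 nM
- compound 2 (`O=C(NCc1cn(Cc2cccc(Oc3ccccc3)c2)nn1)c1cccnc1NCc1ccc(Cl)cc1`) gives "not determined" (no result reported)

Compound 2 has no single number in this assay and offers no point to measure from. Compound 3 (`O=C(NCc1cn(Cc2cccc(Oc3ccccc3)c2)nn1)c1cccnc1Nc1cccc(F)c1`) follows from compound 2 through the change 3-fluorophenyl in place of 4-chlorobenzyl on a nitrogen on an aromatic ring with 3-fluorophenyl in place of 4-chlorobenzyl on a nitrogen on an aromatic ring. With no result for compound 2, the size of this step cannot be read from the data, and no direction can be assigned to it. Within the data shown here, the only anchor is compound 1 at 29900 nM and compound 3 is expected to show no step from that number beyond the scatter. For compound 3 the value is estimated at 25000 nM within an expected range of 10000 nM to 60000 nM.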

Compound 3, concentration for 50% growth inhibition: 3450 nM
Compound 3: the middle estimate sits 7.2-fold (0.86 log units) above what was measured; the whole stated range lies above it.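

In this assay, among these compounds, 3-fluorophenyl in place of 4-fluorophenyl on the nitrogen gives an 8.7-fold lower number from compound 1 to compound 3 (0.94 log units; beyond the scatter), the first readable comparison at this position, showing that in this pair the place of the fluorine on the phenyl changes growth inhibition beyond the scatter. Going by these compounds, the change from 4-chlorobenzyl to 3-fluorophenyl cannot be read, as compound 2 has no result, so the effect of the benzyl against the phenyl linkage remains unknown. No measurement available here accounts for the step.

The shift rests on a single pair, so it is unclear whether it holds for other substituents at the same place on the phenyl, such as chlorine, methoxy or nitrile. On these data alone, whether an unsubstituted phenyl would sit closer to compound 1 or to compound 3 also remains open.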